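Swapping an aryl group on a shared core

The source may report more compounds than this note shows. Statements on the series, on what has been measured and on what is new or still open speak of the compounds shown alone.

Measured so far:
compound 1, `Cn1cc(-c2ccccc2F)c2cc(C(=O)NCc3ccc(C(=O)Nc4ccccc4N)cc3)[nH]c2c1=O`, 230 nM
compound 2, `CC(C)Oc1ccc(C(C)(C)O)cc1-c1cn(C)c(=O)c2[nH]c(C(=O)NCCCCCCC(=O)NO)cc12`, 160 nM

Of the compounds shown here, two have been tested in a functional assay on MV4-11 cells (Homo sapiens) for antiproliferative activity, read by CCK-8 assay, with a stated time of 72 h; a higher number here means a weaker inhibitor, a lower number a stronger inhibitor. Compound 1 gives 230 nM, the higher of the two numbers. Compound 2, which carries a different chain and a different aryl group on the same core, gives 160 nM in this assay; the two values lie within the usual scatter of each other, so neither can be called the stronger inhibitor.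

The next compound, compound 3, `COc1ccc(C(C)(C)O)cc1-c1cn(C)c(=O)c2[nH]c(C(=O)NCc3ccc(C(=O)Nc4ccccc4N)cc3)cc12`, keeps the chain of compound 1 and changes only the aryl group: 5-(1-hydroxy-1-methylethyl)-2-methoxyphenyl in place of 2-fluorophenyl on an aromatic carbon. Within the data shown here, no measured pair differs in exactly this way, so the size of the step cannot be read from the data. Compound 2, whose aryl group also carries a 1-hydroxy-1-methylethyl group, gives 160 nM, a number close to that of compound 1, which suggests that the change does not move the value far.

Compound 3 is therefore expected to give about 180 nM in this assay, in the range 60 nM to 550 nM. The expected step of a 1.3-fold lower number from compound 1 to compound 3 (0.11 log units; within the scatter) stays within the scatter.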

Compound 3, half-maximal inhibitory concentration: 420 nM
The estimate for compound 3 lay 2.3-fold (0.37 log units) below the measured number; the measured number falls inside the stated range.
By their numbers in this assay, from the lowest: compounds 2, 1 and 3 (each within the scatter of the next, the first and the last beyond it).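

In this assay, the step at this position, a 1.8-fold higher number from compound 1 to compound 3 (0.26 log units; within the scatter), lies within the scatter, so this swap cannot be said to change the antiproliferative read-out. It does show that the aromatic carbon ortho to a fused ring can carry 5-(1-hydroxy-1-methylethyl)-2-methoxyphenyl, with 12 heavy atoms, 1 hydrogen-bond donor and 2 hydrogen-bond acceptors, as well as 2-fluorophenyl, with 7 heavy atoms and neither donors nor acceptors, without a step beyond the scatter in this cell assay. No accompanying measurement helps to interpret this single step.

The swap alters the methoxy and 1-hydroxy-1-methylethyl groups together with the loss of fluorine, so the compounds shown leave open what each of these groups contributes on its own, a question that a simple 2-methoxyphenyl group at the same place could begin to address. From the compounds shown here alone, it also remains open whether an aryl group bearing an amine or a carboxylic acid would stay within the scatter at this position, and whether this swap would give a similar step on a different chain.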